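Chloro to methoxy: an estimate for compound 3

The source may hold more compounds than are shown below. What is called first, only, known or untested is meant among the compounds shown, and "the series" means these compounds.

For the measured compounds named here, compound 2 `CCOC(=O)c1c(N)sc(-c2ccc(Cl)cc2)c1-c1cccc(C(F)(F)F)c1` carries a 4-chlorophenyl group and gives in a functional assay on CHO-K1 cells for agonist activity at adenosine receptor A1 (Homo sapiens), read by GTPgammaS binding (a lower number here means that less compound is needed, a higher number that more compound is needed for the effect), a value of 6.6 uM; it is the only compound with a number. Compound 1 `CCOC(=O)c1c(N)sc(-c2cccc(C(C)=O)c2)c1-c1cccc(C(F)(F)F)c1` gives in this assay > 10 uM, a limit of the assay rather than a number. The step of an at least 1.5-fold lower number from compound 1 to compound 2 (0.18 log units; that floor lies within the scatter) therefore has only a floor, because one of the two values sits at the limit (the limit of > 10 uM in this assay, at which 1 of the 2 values shown sits).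

Compound 3 `CCOC(=O)c1c(N)sc(-c2ccc(OC)cc2)c1-c1cccc(C(F)(F)F)c1` differs from compound 2 by methoxy in place of chloro on an aromatic carbon. Going by the values given here, no measured step exchanges chloro for methoxy; the one step available replaces 3-acetylphenyl by 4-chlorophenyl and sets only a floor. Nothing therefore points to a step in this assay beyond the scatter in either direction. Compound 3 is therefore expected to show an estimated step of a 1.1-fold higher number from compound 2 to compound 3 (0.03 log units; within the scatter). For compound 3 the estimate in this assay is 7 uM, between 2 uM and 25 uM.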

Compound 3, concentration for half-maximal effect: > 10 uM
Compound 3: no number, only a limit; the forecaster's own chance of this, stated with the estimate: 35%; at least 1.4-fold (0.15 log units) between middle value and limit.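

For the compounds shown here, the change from 4-chlorophenyl to 4-methoxyphenyl is the first exchange at this place, on an aromatic carbon para to a large group, that leaves the rest of the structure untouched, and it brings an at least 1.5-fold higher number from compound 2 to compound 3 (0.18 log units; that floor lies within the scatter). Going by these compounds, that floor does not establish a step beyond the scatter, and the true size of the step stays unknown. In this assay compound 2 remains the only compound with a number, and the two others end at the same limit: the limit of > 10 uM in this assay, at which 2 of the 3 values shown sit.

The step between compound 1 and compound 3 cannot be read, since both values are limits. Open remains whether a fluoro, methyl or amino group at this place would give a number in this assay, and whether a smaller or larger alkoxy group than methoxy would do so.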